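Sulfonamide series: hydroxy to trifluoromethyl, cytotoxicity check

This account rests on a few compounds, and the source may have more. Where it says the series, first, only, none or still open, it means among the compounds named here.

Among the measured compounds shown here, compound 1 `O=S(=O)(Nc1ccc2oc(-c3ccccc3)nc2c1)c1ccccc1O` is the only member of the set with a numerical read-out in an ADME assay on HEK293 cells (Homo sapiens) for cytotoxicity, read by resazurin assay, with a stated time of 48 h (on this read-out higher numbers stand for lower toxicity in this test and lower numbers for higher toxicity in this test), where compound 1 gives 33000 nM. Compound 2 `O=S(=O)(Nc1ccc(-c2nc3ccccc3o2)cc1)c1cccc(Cl)c1` reaches a limit of the assay in this assay, reported as > 100000 nM. Compound 3 `O=S(=O)(Nc1ccc(-c2nc3ccccc3o2)cc1)c1ccccc1O` likewise sits at a limit in this assay, given as > 100000 nM. For the measured compounds named here, the one measured step, a step that the two limits leave unreadable from compound 2 to compound 3, is therefore unreadable in size because both ends rest at the limit of > 100000 nM in this assay, at which 2 of the 3 values shown sit.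

The step now followed goes from compound 1 to compound 4 `O=S(=O)(Nc1ccc2oc(-c3ccccc3)nc2c1)c1ccccc1C(F)(F)F`, with the change (trifluoromethyl in place of hydroxy on an aromatic carbon). Going by the values given here, no measured step concerns this exchange: the step from compound 2 to compound 3 swaps the whole aryl group on the sulfonyl sulfur and carries no readable size, and the two limits do not locate the two compounds relative to compound 1. The data thus give no direction for the change in this assay, and no step beyond the usual scatter is predicted.

Compound 4 is expected to give about 45000 nM in this assay, estimated between 15000 nM and 150000 nM. The expected step of a 1.4-fold higher number from compound 1 to compound 4 (0.13 log units; within the scatter) is accordingly estimated as small, with a fair chance that only a limit is reported.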

Compound 4, half-maximal cytotoxic concentration: 80000 nM
For compound 4 the middle estimate is 1.8-fold (0.25 log units) below the measured one; the measured number falls inside the stated range.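

In this assay the series now has a readable step at this position, on an aromatic carbon ortho to a large group: a 2.4-fold higher number from compound 1 to compound 4 (0.38 log units; beyond the scatter). The direction is toward lower toxicity in this test, which shows that, on the core of compound 1, the hydroxy group is not required for the higher number and that trifluoromethyl in its place does not lower it. The only step among the earlier compounds cannot be read, so what is known about this exchange rests on this single pair: the limit of > 100000 nM in this assay, at which 2 of the 4 values shown sit.

From the compounds shown here alone, it remains open whether the step follows from the loss of hydroxy or from the arrival of trifluoromethyl, and a methoxy group, an amine or a plain hydrogen at the same place would help separate the two. It also remains open whether the same exchange would give a readable step on the core of compound 3, or on any aryl group on the sulfonyl sulfur other than those shown here.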